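The compounds below may be only part of what the source reports. "The series", "measured", "known", "first", "only" and "open" are said of these compounds alone.

Measured so far:
compound 1, `Oc1ccc(O)c(/C=N/c2ccc(OCc3ccccc3)cc2)c1`: 1230 nM
compound 2, `Oc1cccc(/C=N/c2ccc(OCc3ccccc3)cc2)c1O`: 6870 nM

Among the measured compounds shown here, in an assay on isolated protein for inhibition of Amine oxidase [flavin-containing] B (Homo sapiens), read by fluorescence and Amplex Red, with stated times of 15 min and 20 min (on this read-out higher numbers stand for weaker inhibition and lower numbers for stronger inhibition), compound 2 stands at the highest number of the two, with compound 1 as its only neighbour. For the measured compounds named here, the one measured step, a 5.6-fold higher number from compound 1 to compound 2 (0.75 log units; beyond the scatter), goes with 2,3-dihydroxyphenyl in place of 2,5-dihydroxyphenyl on a carbon with a double bond to nitrogen. Compound 3, `Oc1ccc(Br)cc1/C=N/c1ccc(OCc2ccccc2)cc1`, has not yet been measured. It differs from compound 2 by 5-bromo-2-hydroxyphenyl in place of 2,3-dihydroxyphenyl on a carbon with a double bond to nitrogen. Going by the values given here, no measured step bears on this change directly; the step from compound 1 to compound 2 only shows that altering the hydroxyls on this ring shifts the number beyond the scatter, and neither measured compound carries a bromine. Compound 3 keeps a single hydroxyl in its 5-bromo-2-hydroxyphenyl group, and a step of an 8.6-fold lower number from compound 2 to compound 3 (0.93 log units; beyond the scatter) toward a lower number is expected, with little to anchor it. For compound 3 the estimate is 800 nM in this assay, with a range from 150 nM to 4500 nM.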

Compound 3, half-maximal inhibitory concentration: 31700 nM
Estimate against measurement, compound 3: 40-fold (1.60 log units) below, outside the stated range (above it).
By their numbers in this assay, from the lowest: compound 1; then compound 2; then compound 3.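

In this assay, the 5-bromo-2-hydroxyphenyl group proves a poor replacement for 2,3-dihydroxyphenyl on the carbon with a double bond to nitrogen, giving a 4.6-fold higher number from compound 2 to compound 3 (0.66 log units; beyond the scatter) rather than any gain. Bromo in place of hydroxy on an aromatic carbon has the greater consequence, with a 26-fold higher number from compound 1 to compound 3 (1.41 log units; beyond the scatter) in a large step. This shows that a change at this one ring position can carry the number well beyond what moving a hydroxyl showed, and compound 1 keeps the lowest number of the three. Nothing available accounts for this result. Going by these compounds, what a chloro or methoxy group would give in place of the bromo stays open, so it cannot be said whether the rise is particular to bromine or follows from losing the hydroxy.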